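The compounds below may be only part of what the source reports. "The series", "measured", "known", "first", "only" and "open" are said of these compounds alone.

Measured compounds in a functional assay on cells for antagonist activity at Glucagon receptor (Homo sapiens), read by cAMP accumulation, in the presence of a further agent that is not named here; a higher number here means a weaker inhibitor, a lower number a stronger inhibitor:
- compound 1 `CCCC(Oc1ccc(-n2cc(C(=O)N(C)C)cn2)cc1)c1ccc(C(=O)NCCC(=O)O)cc1`: > 30000 nM
- compound 2 `O=C(O)CCNC(=O)c1ccc(C(Oc2ccc(-n3cc(C(F)(F)F)cn3)cc2)C2CCCC2)cc1`: 4000 nM
- compound 3 `CCCC(Nc1ccc(-n2cnc(C(F)(F)F)c2)cc1)c1ccc(C(=O)NCCC(=O)O)cc1`: 4700 nM

Compound 1 stands at the limit of > 30000 nM in this assay, at which 1 of the 3 values shown sits; in this assay its result is a limit and not a number, so it cannot be ranked against the others. Compound 2 gives 4000 nM and compound 3 gives 4700 nM in this assay; these two values lie within the usual scatter of each other, and both carry a trifluoromethyl on the azole, while differing from compound 1 in several places at once, so no single step can be read from them.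

Compound 4 `CCCC(Oc1ccc(-n2cc(Cl)cn2)cc1)c1ccc(C(=O)NCCC(=O)O)cc1` has not been measured in this assay. It differs from compound 1 by chloro in place of dimethylcarbamoyl on an aromatic carbon. With compound 1 at a limit, the step cannot be sized from measured pairs; the expectation is a move toward the region where compounds 2 and 3 sit, expressed as the estimated step of an at least 3.3-fold lower number from compound 1 to compound 4 (0.52 log units; beyond the scatter) in this assay. Compound 4 is estimated at 9000 nM in this assay, with a range from 2500 nM to 40000 nM.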

Compound 4, antagonist equilibrium constant: 6500 nM
Beside the measured number, compound 4's estimate is 1.4-fold (0.14 log units) above it, and the stated range covers the measured number.
By their numbers in this assay, from the lowest: compounds 2, 3 and 4 (each within the scatter of the next). At a limit, above all of these: compound 1.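

In this assay, the change from 4-(dimethylcarbamoyl)-1H-pyrazol-1-yl to 4-chloro-1H-pyrazol-1-yl gives an at least 4.6-fold lower number from compound 1 to compound 4 (0.66 log units; beyond the scatter). Within the data shown here, this is the first step that can be read at a single place, and it shows that the result depends on the group on this aromatic carbon of the five-membered ring: with the rest of the core unchanged, chloro gives a measurable value where dimethylcarbamoyl does not. The size of the step is only a lower bound, since one of its ends is a limit: the limit of > 30000 nM in this assay, at which 1 of the 4 values shown sits.

On these data alone, whether the shift comes from chloro itself or from the loss of dimethylcarbamoyl stays open; a hydrogen, a methyl or a nitrile at this carbon would separate the two. Steps linking compound 2 or compound 3 to compound 4 cannot be read, as these compounds differ in several places.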